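Imidazole for thiazolylamine on a short-lived core

The source may hold more compounds than are shown below. What is called first, only, known or untested is meant among the compounds shown, and "the series" means these compounds.

Three compounds have results in an ADME assay on microsomes from liver (Mus musculus) for metabolic stability; on this read-out higher numbers stand for a longer-lived compound and lower numbers for a shorter-lived compound. Compound 1 `CCn1ncc2c(F)cc(-c3ccc(C(CC)(CC)c4nnc[nH]4)c(=O)[nH]3)cc21` reaches only the upper limit of the assay, which is a limit and not a number: > 3 h. Compound 3 `CCn1ncc2c(F)cc(-c3ccc(C(CC)(CC)c4ncn(C)n4)c(=O)[nH]3)cc21` likewise returns a limit, > 3 h. The step that the two limits leave unreadable from compound 1 to compound 3 therefore cannot be sized. Compound 2 `CC(C)C(Nc1nccs1)c1ccc(-c2ccc3cccc(F)c3c2)[nH]c1=O`, built on a different core, is the only one of the three with a real number; in this assay compound 2 gives 0.0733 h, a very short half-life, while (the limit of > 3 h in this assay, at which 2 of the 3 values shown sit).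

Compound 4 `Cc1c[nH]c(C(c2ccc(-c3ccc4cccc(F)c4c3)[nH]c2=O)C(C)C)n1` differs from compound 2 in one place: 4-methyl-1H-imidazol-2-yl in place of (1,3-thiazol-2-yl)amino on a saturated chain carbon bound to an aromatic carbon and a saturated chain carbon. For the measured compounds named here, no measured step involves this exchange. Going by the values given here, the single measured step, between compound 1 and compound 3, concerns another change on another core and is unreadable in any case, so it offers no direction for compound 4. With nothing to point one way or the other, the expected step of a 1.6-fold higher number from compound 2 to compound 4 (0.21 log units; within the scatter) is small, lying within the usual scatter, though the uncertainty is wide. Compound 4 is therefore estimated at 0.12 h in this assay, expected to fall between 0.03 h and 0.6 h.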

Compound 4, half-life: < 0.0667 h
Compound 4: only a limit was reported; the forecaster's own chance of this, stated with the estimate: 5%; at least 1.7-fold (0.25 log units) between middle value and limit.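

Compound 4 sits at a limit of this assay, which is not a number: the limit of < 0.0667 h in this assay, at which 1 of the 4 values shown sits.

At this saturated chain carbon, 4-methyl-1H-imidazol-2-yl in place of (1,3-thiazol-2-yl)amino gives an at least 1.0-fold lower number from compound 2 to compound 4 (0.04 log units; that floor lies within the scatter), so exchanging one five-membered aromatic ring with 2 hetero atoms for another does not produce a longer-lived compound. For the compounds shown here, the earlier compounds gave no reading at this place, as their single step lay on another core and could not be read. Since the floor of the new step lies within the scatter, the result does not establish a real loss either, and it gives no upper bound on the size of the step.

As far as these compounds go, how far compound 4 truly lies under its limit stays open, and so does the true gap to compound 2. Also open is whether a group of a different kind at this place, such as a carboxylic acid or a primary amine, would change the half-life on this core at all, as both groups shown here are five-membered aromatic rings of the same heavy-atom count.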